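A few compounds are considered here, and "the series" means these few. Any claim that something is new, unique, unknown or untested is made for them only; others in the source may bear on it.

In a functional assay on G-361 cells (Homo sapiens) for inhibition, with a stated time of 72 h (on this read-out higher numbers stand for weaker inhibition and lower numbers for stronger inhibition), compound 1 `NC1CCC(Nc2nc(NCc3ccc(-c4ccccc4)cc3)c3ncn(C4CCCC4)c3n2)CC1` gives 1020 nM and compound 2 `NC1CCC(Nc2nc(NCc3ccc(-c4ccccc4)nc3)c3ncn(C4CCCC4)c3n2)CC1` gives 895 nM, so compound 2 stands level with compound 1 within the scatter. Compound 3 `NC1CCC(Nc2nc(NCc3cc(Cl)ccc3O)c3ncn(C4CCCC4)c3n2)CC1` has 5-chloro-2-hydroxyphenyl in place of 6-phenylpyridin-3-yl on a saturated chain carbon bound to a nitrogen on an aromatic ring. Among the compounds with values here, the only measured step at this place, a 1.1-fold lower number from compound 1 to compound 2 (0.06 log units; within the scatter), stayed within the scatter, but no measured compound carries the entering group. The step expected in this assay is therefore a 1.0-fold higher number from compound 2 to compound 3 (0.00 log units; within the scatter), with no shift beyond the scatter and no favoured direction. For compound 3 the estimated value is 900 nM, with an expected range of 250 nM to 3200 nM.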

Compound 3, half-maximal inhibitory concentration: 390 nM
The estimate for compound 3 lay 2.3-fold (0.36 log units) above the measured number, within the range that was stated.
By their numbers in this assay, from the lowest: compound 3; then compounds 2 and 1 (each within the scatter of the next).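

In this assay, this position on a saturated chain carbon bound to a nitrogen on an aromatic ring proves sensitive to the group it carries, which the earlier pair did not show. The single-ring 5-chloro-2-hydroxyphenyl gives modest gains over both 6-phenylpyridin-3-yl (a 2.3-fold lower number from compound 2 to compound 3 (0.36 log units; beyond the scatter)) and 4-phenylphenyl (a 2.6-fold lower number from compound 1 to compound 3 (0.42 log units; beyond the scatter)), so the second aromatic ring is not required for this level of inhibition. Nothing available explains this shift.

The compounds shown do not separate the contributions of the chlorine and the hydroxyl. On these data alone, whether an amine or a carboxylic acid in place of that hydroxyl would keep the gain also stays open.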